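The source may report more compounds than this note shows. Statements on the series, on what has been measured and on what is new or still open speak of the compounds shown alone.

Of the compounds shown here, two that share a core have been measured so far. In a functional assay on NB-4 cells (Homo sapiens) for inhibition, read by XTT assay, with a stated time of 48 h (a higher number here means a weaker inhibitor, a lower number a stronger inhibitor), compound 1 (`COc1ccc(C(=O)/C(=C/c2ccccc2F)COC(C)=O)cc1`) gives 8200 nM and compound 2 (`COc1ccc(C(=O)/C(=C/C2CCCCC2)COC(C)=O)cc1`) gives 23300 nM. Compound 2 therefore has the higher of the two numbers and is the weaker inhibitor of this pair.

Compound 3 (`COc1ccc(C(=O)/C(=C/C2CCCCC2)CC(C)OC(C)=O)cc1`) has not yet been measured. It keeps the cyclohexyl group of compound 2 and differs in a single place, with 1-acetoxyethyl in place of acetoxy on a saturated chain carbon bound to a double-bonded chain carbon. The same change can also be read as acetoxymethyl to 2-acetoxypropyl.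

For the measured compounds named here, only one measured step is available for comparison: a 2.8-fold higher number from compound 1 to compound 2 (0.45 log units; beyond the scatter), which came from cyclohexyl in place of 2-fluorophenyl. That step was modest and involved a different group, so it gives a rough scale for what one change can do here but no direction for this one. Going by the values given here, no measured pair tests the acetoxy side of the molecule, so no shift beyond the scatter is expected. The expected step is a 1.0-fold lower number from compound 2 to compound 3 (0.01 log units; within the scatter). For compound 3 the estimated value is 23000 nM, with an expected range from 10000 nM to 52000 nM.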

Compound 3, half-maximal inhibitory concentration: 33400 nM
Beside the measured number, compound 3's estimate is 1.5-fold (0.16 log units) below it; the measured number falls inside the stated range.
By their numbers in this assay, from the lowest: compound 1; then compounds 2 and 3 (each within the scatter of the next).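

In this assay, putting 1-acetoxyethyl in place of acetoxy on a saturated chain carbon bound to a double-bonded chain carbon gives a 1.4-fold higher number from compound 2 to compound 3 (0.16 log units; within the scatter). For the compounds shown here, this is the first measured change on the acetoxy side of the molecule, and it shows that, with cyclohexyl in place, going from acetoxymethyl to 2-acetoxypropyl leaves the number within the scatter, whereas the earlier change at the other site gave a 2.8-fold higher number from compound 1 to compound 2 (0.45 log units; beyond the scatter). Nothing measured here bears on why this change leaves the number within the scatter.

The acetoxy group itself is present in all the compounds shown, so it remains open how the number would respond to a different end on this chain, such as a free hydroxyl, an amine or a carboxylic acid. On these data alone, it also remains open whether the same chain change would read the same way with 2-fluorophenyl in place of cyclohexyl, as in compound 1, or whether a still longer chain would stay within the scatter.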